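The compounds below may be only part of what the source reports. "The series", "measured", "known", "first", "only" and "open" are said of these compounds alone.

Measured compounds:
- compound 1 `c1ccc(Cn2nnc3c(NC4CCCCC4)ncnc32)cc1` — in an assay on cell membranes for binding affinity to adenosine receptor A1 (Bos taurus), read by radioligand binding (on this read-out lower numbers stand for stronger inhibition and higher numbers for weaker inhibition), compound 1 gives 121 nM
- compound 2 `Clc1ccccc1Cn1nnc2c(NC3CCCC3)ncnc21` — in this assay compound 2 gives 21 nM

Going by the values given here, of the two numbers so far, compound 2 holds the lower one; compound 1 stands higher, and the gap between them goes beyond the usual scatter. Compound 3 `Clc1ccccc1Cn1nnc2c(NCC3CCCCC3)ncnc21` is not yet measured. Set next to compound 2, it differs in one place: cyclohexylmethyl in place of cyclopentyl on a nitrogen on an aromatic ring. Among the compounds with values here, no measured pair shows this kind of change, so there is no direct guide. A weaker binding is nevertheless expected for compound 3, with the step of a 3.8-fold higher number from compound 2 to compound 3 (0.58 log units; beyond the scatter) in this assay likely beyond the scatter. For compound 3 the expected value is 80 nM, within 25 nM to 300 nM.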

Compound 3, inhibition constant: 4260 nM
Beside the measured number, compound 3's estimate is 53-fold (1.73 log units) below it; the whole stated range lies below it.
By their numbers in this assay, from the lowest: compound 2; then compound 1; then compound 3.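

In this assay, the group on the nitrogen on the aromatic ring proves to be a sensitive point: with the rest of the molecule unchanged, cyclohexylmethyl in place of cyclopentyl gives a 200-fold higher number from compound 2 to compound 3 (2.31 log units; beyond the scatter). This is the first change in a single place among these compounds, and it shows that binding can be lost almost entirely through this one group. Nothing measured here explains the loss.

Going by these compounds, whether the loss follows the larger ring or the added carbon link stays open. Cyclopentylmethyl on this nitrogen would help separate the two.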